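The source may hold more compounds than are shown below. What is called first, only, known or untested is meant among the compounds shown, and "the series" means these compounds.

In a functional assay on SMMC-7721 cells (Homo sapiens) for cytotoxicity, read by MTT assay, with a stated time of 24 h (a higher number here means a weaker inhibitor, a lower number a stronger inhibitor), compound 1 `Cc1ccc(S(=O)(=O)N2C/C(=C\c3cccnc3)C(=O)/C(=C/c3ccccc3C(F)(F)F)C2)cc1` gives 6700 nM and compound 2 `O=C1/C(=C/c2cccnc2)CN(S(=O)(=O)c2ccc(F)cc2)C/C1=C\c1ccccc1C(F)(F)F` gives 6390 nM, so the two stand level within the scatter. Among the measured compounds shown here, the only measured step, a 1.0-fold lower number from compound 1 to compound 2 (0.02 log units; within the scatter), is fluoro in place of methyl on an aromatic carbon, and it does not touch the group changed next. Compound 3 `Cc1ccc(S(=O)(=O)N2C/C(=C\c3ccncc3)C(=O)/C(=C/c3ccccc3C(F)(F)F)C2)cc1` differs from compound 1 by pyridin-4-yl in place of pyridin-3-yl on a double-bonded chain carbon bound to a double-bonded ring carbon. For the measured compounds named here, no measured step covers this change, so no shift beyond the scatter is expected in this assay. The expected step is a 1.1-fold lower number from compound 1 to compound 3 (0.05 log units; within the scatter). For compound 3 the estimated value is 6000 nM, with an expected range of 2500 nM to 14000 nM.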

Compound 3, half-maximal inhibitory concentration: 5590 nM
Beside the measured number, compound 3's estimate is 1.1-fold (0.03 log units) above it; the measured number falls inside the stated range.
By their numbers in this assay, from the lowest: compounds 3, 2 and 1 (each within the scatter of the next).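

In this assay the position on a double-bonded chain carbon bound to a double-bonded ring carbon gets its first reading: pyridin-4-yl in place of pyridin-3-yl gives a 1.2-fold lower number from compound 1 to compound 3 (0.08 log units; within the scatter). Either pyridinyl group is therefore accepted at this position in this assay, so the attachment point of the pyridine makes no readable difference for this pair. Nothing available bears on a cause for this result. Open, as far as these compounds go, is whether a pyridin-2-yl group, or an amine or a carboxylic acid on the pyridine ring, would move the number beyond the scatter. From the compounds shown here alone, whether the same level holds with the other substituted aromatic groups on the shared core also remains open.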